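Halogen swap on the fused ring of the benzothiazole series

This account rests on a few compounds, and the source may have more. Where it says the series, first, only, none or still open, it means among the compounds named here.

Compound 1 `COc1ccc(-c2nc3cc(F)ccc3s2)cc1Cl` and compound 2 `COc1ccc(-c2nc3cc(F)ccc3s2)cc1Br` share a core and differ only in the halogen on the methoxy-bearing ring. In a functional assay on HCC 2998 cells (Homo sapiens) for antiproliferative activity (a lower number here means a stronger inhibitor of growth, a higher number a weaker inhibitor of growth), compound 1 gives 2500 nM and compound 2 gives 3450 nM; the step is a 1.4-fold higher number from compound 1 to compound 2 (0.14 log units; within the scatter), the change being (bromo in place of chloro on an aromatic carbon). Compound 3 `COc1ccc(-c2nc3cc(Cl)ccc3s2)cc1OC` carries a dimethoxy-substituted ring and a chloro on the fused ring; in this assay compound 3 gives 4880 nM. How the core of compound 3 differs from that of compound 1 is not broken down here. Compound 4 `COc1ccc(-c2nc3cc(Br)ccc3s2)cc1OC` is still unmeasured; it differs from compound 3 by bromo in place of chloro on an aromatic carbon. This is the same kind of change as from compound 1 to compound 2 but not the same: there the place was ortho to a methoxy group and meta to a large group on a six-membered ring of carbon only, here it is on a ring that is part of a fused system, meta and para to a fused ring. Going by the values given here, since the only measured chloro-to-bromo step, a 1.4-fold higher number from compound 1 to compound 2 (0.14 log units; within the scatter), lies within the scatter, a step of similar size is expected for compound 4, a 1.2-fold higher number from compound 3 to compound 4 (0.09 log units; within the scatter), giving an estimated 6000 nM in this assay, with a range of 3000 nM to 12000 nM.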

Compound 4, concentration for 50% growth inhibition: 20000 nM
Compound 4: middle estimate off by 3.3-fold (0.52 log units), on the low side; measured number above the stated range.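

On the core of compound 3, bromo in place of chloro on an aromatic carbon gives a 4.1-fold higher number from compound 3 to compound 4 (0.61 log units; beyond the scatter) in this assay, so on this core the swap costs growth inhibition by more than the usual scatter. Set beside the earlier step, the same change does not keep its size from one core to the other: the same change on two cores in this assay, a 1.4-fold higher number (0.14 log units; within the scatter) from compound 1 to compound 2 and a 4.1-fold higher number (0.61 log units; beyond the scatter) from compound 3 to compound 4, 3.0-fold (0.47 log units) apart, beyond the scatter of two such steps This shows that a chloro-to-bromo step measured on one core cannot be carried unchanged to another in this series, but with only one pair per core, and with the halogen on a different ring in each pair, it does not show what sets the size of the step.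

The compounds shown leave open whether the larger step follows the place on the fused system or the rest of the core, as no pair makes the swap at both places on one core. Also open, going by these compounds, is how an amine or a carboxylic acid at that place on the fused system would compare with chloro and bromo.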